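The source may report more compounds than this note shows. Statements on the series, on what has been measured and on what is new or still open speak of the compounds shown alone.

Three measured compounds share one core and differ only in the group on the carbonyl carbon of the amide. Compound 1 `CC(=O)N(C)c1ccc2[nH]c(-c3n[nH]c4ccccc34)cc2n1` carries a methyl there; in a functional assay on SMMC-7721 cells (Homo sapiens) for antiproliferative activity, read by MTT assay, with a stated time of 72 h (a lower number here means a stronger inhibitor, a higher number a weaker inhibitor), compound 1 gives 23400 nM. Compound 2 `CN(C(=O)c1ccccc1)c1ccc2[nH]c(-c3n[nH]c4ccccc34)cc2n1` carries a phenyl, and in this assay compound 2 gives 12500 nM. Compound 3 `CN(C(=O)c1ccco1)c1ccc2[nH]c(-c3n[nH]c4ccccc34)cc2n1` carries a furan-2-yl, and in this assay compound 3 gives 28200 nM. Among the three numbers compound 2 stands lowest: the change a 1.9-fold lower number from compound 1 to compound 2 (0.27 log units; within the scatter) is within the scatter, while a 2.3-fold higher number from compound 2 to compound 3 (0.35 log units; beyond the scatter) is a modest step beyond it, and a 1.2-fold higher number from compound 1 to compound 3 (0.08 log units; within the scatter) is again within the scatter.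

Compound 4 `Cc1ccc(S(=O)(=O)N(C)c2ccc3[nH]c(-c4n[nH]c5ccccc45)cc3n2)cc1` is the next compound to be measured. It differs from compound 2 in one place: (4-methylphenyl)sulfonyl in place of benzoyl on a nitrogen on an aromatic ring. Going by the values given here, nothing measured so far bears directly on this change, since each measured step swaps one group for another on a carbonyl carbon, and none brings in a (4-methylphenyl)sulfonyl. Among the compounds with values here, the only guide is that the three variations at this position moved this assay little. Compound 4 is therefore expected to sit near compound 2, with a step of a 1.2-fold higher number from compound 2 to compound 4 (0.08 log units; within the scatter) expected to stay within the scatter. Compound 4 is estimated at 15000 nM in this assay, with a range from 5000 nM to 45000 nM.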

Compound 4, half-maximal inhibitory concentration: 16300 nM
Compound 4: middle estimate off by 1.1-fold (0.04 log units), on the low side, within the range that was stated.
By their numbers in this assay, from the lowest: compounds 2, 4, 1 and 3 (each within the scatter of the next, the first and the last beyond it).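

Compound 4 shows that at this nitrogen on an aromatic ring the carbonyl link itself can be exchanged, not only the group it carries: with (4-methylphenyl)sulfonyl in place of benzoyl, this assay gives a 1.3-fold higher number from compound 2 to compound 4 (0.12 log units; within the scatter) and so stays close to the benzoyl compound. The comparisons with the other two groups read the same way, with a 1.7-fold lower number from compound 3 to compound 4 (0.24 log units; within the scatter) against the (furan-2-yl)carbonyl compound and a 1.4-fold lower number from compound 1 to compound 4 (0.16 log units; within the scatter) against the acetyl compound, so compound 4 lies within the scatter of all three earlier compounds, including the pair of compound 2 and compound 3 that are separated beyond it. Nothing shown here accounts for why this exchange leaves the number so nearly in place.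

On these data alone, all four compounds keep the methyl on this nitrogen and carry an acyl or sulfonyl group there, so it remains open what a free amine, a urea, a carbamate or a plain ethyl group at this place would do. Also open, as far as these compounds go, is whether a sulfonyl carrying only a methyl, or a benzene ring bearing a chlorine or a methoxy group, would produce a step beyond the scatter.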